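The source may hold more compounds than are shown below. What is called first, only, known or untested is meant among the compounds shown, and "the series" means these compounds.

Measured so far in a functional assay on FM3A cells (Mus musculus) for inhibition, read by cell counting, with a stated time of 2 days; a higher number here means a weaker inhibitor, a lower number a stronger inhibitor:
compound 1, `C=C(Br)C(=O)Nc1cccc(-c2cn3nc(Cc4cccc(OC)c4)sc3n2)c1`, 1100 nM
compound 2, `Nc1cccc(-c2cn3c(-c4ccccc4)csc3n2)c1`, 34000 nM
compound 3, `COc1cccc(Cc2nn3cc(-c4cccc(N)c4)nc3s2)c1`, 10000 nM

Compound 1 holds the lowest number of the three in this assay. Among the measured compounds shown here, its nearest neighbour is compound 3, and the only single-point step in the set is a 9.1-fold higher number from compound 1 to compound 3 (0.96 log units; beyond the scatter), the change being hydrogen in place of (1-bromoethenyl)carbonyl on a nitrogen on an aromatic ring. Compound 2 differs from compound 1 in more than one place, so only the two values can be set side by side: compound 2 sits furthest from compound 1, and the gap lies beyond the scatter.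

The next compound is compound 4, `C=C(Br)C(=O)Nc1cccc(-c2cn3nc(-c4ccc(OC)cc4)sc3n2)c1`. Relative to compound 1 the change is 4-methoxyphenyl in place of 3-methoxybenzyl on an aromatic carbon. For the measured compounds named here, no measured step bears on this part of the molecule: the step from compound 1 to compound 3 concerns the amide end and leaves the group on the five-membered ring untouched, and compound 2 carries a different substitution pattern on the shared core altogether. The (1-bromoethenyl)carbonyl group that distinguishes compound 1 from compound 3 is kept in compound 4. With no guidance from the data on the methoxy-bearing ring, a step within the scatter or a small rise is expected, as a 1.8-fold higher number from compound 1 to compound 4 (0.26 log units; within the scatter). For compound 4 the estimate in this assay is 2000 nM, with a range from 500 nM to 8000 nM.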

Compound 4, half-maximal inhibitory concentration: 890 nM
Estimate against measurement, compound 4: 2.2-fold (0.35 log units) above; the range from low to high includes it.
By their numbers in this assay, from the lowest: compounds 4 and 1 (each within the scatter of the next); then compound 3; then compound 2.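

In this assay, among the compounds shown here, the step at the aromatic carbon next to the ring sulfur and the ring nitrogen, a 1.2-fold lower number from compound 1 to compound 4 (0.09 log units; within the scatter), gives the first reading on this position: 4-methoxyphenyl and 3-methoxybenzyl leave compound 1 and compound 4 within the scatter of each other. The exchange alters two features at once, removing the carbon link to the six-membered aromatic ring and moving the methoxy group on that ring, so this pair shows only the outcome of the combined change and cannot assign any share of it to either feature. No measured evidence on the series explains why the values stay so close.

Still open, as far as these compounds go, is how each feature acts alone, which 3-methoxyphenyl and 4-methoxybenzyl at this carbon would address, and whether groups such as unsubstituted phenyl, 4-hydroxyphenyl or a longer alkyl chain fit here as well. Also open, from the compounds shown here alone, is whether an amine in place of the (1-bromoethenyl)carbonyl group would cost as much alongside 4-methoxyphenyl as it does alongside 3-methoxybenzyl in the step of a 9.1-fold higher number from compound 1 to compound 3 (0.96 log units; beyond the scatter).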